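Moving the Sulfur Within a Thiophene on a Chalcone

The source may hold more compounds than are shown below. What is called first, only, known or untested is meant among the compounds shown, and "the series" means these compounds.

Compound 1 `O=C(/C=C/c1ccsc1)c1cc(O)c(O)c([N+](=O)[O-])c1` is tested in an assay on isolated protein for inhibition of Amine oxidase [flavin-containing] B (Homo sapiens), read by fluorescence (on this read-out higher numbers stand for weaker inhibition and lower numbers for stronger inhibition), where compound 1 gives 42100 nM. Two cyclic relatives share its nitro-catechol part: compound 2 `CC(=O)N1N=C(c2cc(O)c(O)c([N+](=O)[O-])c2)CC1c1ccco1` gives 77400 nM in this assay, and compound 3 `CC(=O)N1N=C(c2cc(O)c(O)c([N+](=O)[O-])c2)CC1c1nccs1` gives 68200 nM. Compound 1 sits at the low end of these three numbers, yet its gaps to compound 3 and to compound 2 are both within the usual scatter, so the three cannot be told apart on this evidence.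

Compound 4 `O=C(/C=C/c1cccs1)c1cc(O)c(O)c([N+](=O)[O-])c1` is not yet measured. It differs from compound 1 by thiophen-2-yl in place of thiophen-3-yl on a double-bonded chain carbon bound to a double-bonded chain carbon, so the same atoms are joined differently. For the measured compounds named here, the only measured step, a 1.1-fold lower number from compound 2 to compound 3 (0.05 log units; within the scatter), also swaps one five-membered aromatic ring for another but on a saturated ring carbon, and it stayed within the scatter. Going by the values given here, no measured step touches the double-bonded chain carbon, so there is no direct guide, and the expectation is a step no larger than the scatter in this assay: a 1.1-fold lower number from compound 1 to compound 4 (0.02 log units; within the scatter). Compound 4 is therefore estimated at 40000 nM, within a range from 15000 nM to 110000 nM.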

Compound 4, half-maximal inhibitory concentration: 62900 nM
The estimate for compound 4 lay 1.6-fold (0.20 log units) below the measured number; low and high end bracket the measured number.
By their numbers in this assay, from the lowest: compounds 1, 4, 3 and 2 (each within the scatter of the next).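

Putting thiophen-2-yl in place of thiophen-3-yl on a double-bonded chain carbon bound to a double-bonded chain carbon gives a 1.5-fold higher number from compound 1 to compound 4 (0.17 log units; within the scatter) in this assay. For the compounds shown here, this is the first measured change at this position, and it shows that joining the same atoms differently here leaves the two compounds indistinguishable on this read-out. No supporting data bear on this result.

From the compounds shown here alone, whether a phenyl ring or an amine in that place would move the number beyond the scatter remains open. So does whether a change elsewhere in the shared core, such as a nitrile in place of the nitro group, would separate compounds that so far cannot be told apart.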